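The source may report more compounds than this note shows. Statements on the series, on what has been measured and on what is new or still open speak of the compounds shown alone.

Measured compounds:
- compound 1, `CCCCCCCCN1C(=O)CCc2cc(-n3cnnc3)ccc21`, 300 mg/kg
- compound 2, `O=C1CCc2cc(-n3cnnc3)ccc2N1Cc1ccccc1Cl`, 300 mg/kg
- compound 3, `CCCCCCN1C(=O)CCc2cc(-n3cnnc3)ccc21`, 300 mg/kg

All three compounds were tested in a functional assay on the whole organism (strain KunMing) with Mus musculus as the target, in the maximal electroshock model, with a stated time of 4 h; on this read-out lower numbers stand for an effect already at smaller amounts and higher numbers for an effect only at larger amounts of compound. In this assay, going by the values given here, compound 1 gives 300 mg/kg, compound 2 gives 300 mg/kg and compound 3 gives 300 mg/kg; the three values lie level with one another, and compound 1 stands among them with no step to either neighbour beyond the scatter.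

Compound 4, `O=C1CCc2cc(-n3cnnc3)ccc2N1Cc1ccc(Cl)cc1Cl`, has not yet been measured. Its difference from compound 1 is 2,4-dichlorophenyl in place of heptyl on a saturated chain carbon bound to an amide-type nitrogen in a ring.

Among the compounds with values here, two measured steps bear on this change. The step from compound 1 to compound 2, which also exchanges the heptyl for a chlorine-bearing phenyl at the same place, gave no change at the digits printed from compound 1 to compound 2 (within the scatter). The step from compound 2 to compound 3 gave no change at the digits printed from compound 2 to compound 3 (within the scatter), and the shortening of the chain from compound 1 to compound 3 gave no change at the digits printed from compound 1 to compound 3 (within the scatter). Nothing among these values moved the read-out, so a second chlorine on the ring is expected to leave the dose about where it is, with the step of no change at the digits printed from compound 1 to compound 4 (within the scatter) expected to stay within the scatter. For compound 4 the estimate is therefore 300 mg/kg, in the range 100 mg/kg to 600 mg/kg.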

Compound 4, minimum effective dose: 300 mg/kg
The estimate for compound 4 equals the measured number at the digits printed; the range from low to high includes it.
By their numbers in this assay, from the lowest: compounds 1, 2, 3 and 4 (each within the scatter of the next).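

In this assay, going by these compounds alone, the earlier compounds only exchanged one whole group for another, whereas here a change is made on the aromatic ring itself: chloro in place of hydrogen on an aromatic carbon gives no change at the digits printed from compound 2 to compound 4 (within the scatter). Set against the open chains, 2,4-dichlorophenyl in place of heptyl gives no change at the digits printed from compound 1 to compound 4 (within the scatter), and in place of pentyl it gives no change at the digits printed from compound 3 to compound 4 (within the scatter), so at this place, on a saturated chain carbon bound to an amide-type nitrogen in a ring, the group with two chlorines stands level with both chains and with the group carrying one chlorine. No measurement is available that could explain this flat result.

From the compounds shown here alone, all four compounds carry only plain carbon chains or chlorine-bearing phenyl groups at this place, so it stays open whether an amine, a carboxylic acid or a short methyl group there would move the dose away from the level of compound 4 at 300 mg/kg. Going by these compounds, it also stays open whether any change to the shared core, rather than to this group, would move the read-out at all.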